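The source may report more compounds than this note shows. Statements on the series, on what has been measured and on what is new or still open speak of the compounds shown alone.

Measured so far in an assay on the whole organism (plasma, strain Sprague-Dawley) for inhibition of Dipeptidyl peptidase 4 (Rattus norvegicus), with a stated time of 6 h, at a dose of 1 mg/kg by the oral route; a higher number here means more inhibition at the dose given (going by the name of the read-out), a lower number less inhibition:
compound 1, `CCN(CC)C(=O)[C@@H]1CN[C@H](C(=O)N2CCC[C@H]2C#N)C1`, gives 43%;
compound 2, `C[C@@H]1N[C@H](C(=O)N2CCC[C@H]2C#N)C[C@@H]1C(=O)N1CCOCC1`, gives 94%;
compound 3, `N#C[C@@H]1CCCN1C(=O)[C@@H]1CCCN1`, gives 20%.

Compound 1 stands second highest of the three numbers. Its nearest neighbour is compound 3, reached by a number 23 percentage points lower from compound 1 to compound 3 (beyond the scatter), where hydrogen replaces the diethylcarbamoyl on a saturated ring carbon. For the measured compounds named here, compound 2, which carries a different amide together with an added methyl on the shared core, sits well above both; no single step connects it to compound 1, so the two values are only read side by side.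

The step to compound 4, `N#C[C@@H]1CCCN1C(=O)[C@@H]1C[C@H](C(=O)N2CCC2)CN1`, is azetidin-1-yl in place of diethylamino on a carbonyl carbon. Going by the values given here, only the step to compound 3 bears on it, and that step shows how much is lost when the whole carbamoyl is taken away. Here the carbonyl remains and a cyclic amine replaces the open one, so the change is expected to be modest, with no clear direction beyond the scatter. Compound 4 is therefore estimated at 50%, between 25% and 75%, which would mean a step of a number 7 percentage points higher from compound 1 to compound 4 (within the scatter).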

Compound 4, a percentage reported as inhibition, in the whole organism at one dose (the size of the read-out at that dose, not a potency): 77%
The estimate for compound 4 lay 27 percentage points below the measured number, outside the stated range (above it).
By their numbers in this assay, from the lowest: compound 3; then compound 1; then compound 4; then compound 2.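

In this assay, the change on the carbonyl carbon gives a number 34 percentage points higher from compound 1 to compound 4 (beyond the scatter) and shows that the amine carried by the carbonyl matters, not only the presence of the carbamoyl. For the compounds shown here, measured from hydrogen on the saturated ring carbon, (azetidin-1-yl)carbonyl brings a number 57 percentage points higher from compound 3 to compound 4 (beyond the scatter) and so gives a far larger step than the earlier compounds showed for this position. What the group adds therefore depends strongly on its amine, at least across compound 1 and compound 4. Nothing available explains this difference between the open amine and the four-membered ring.

The compounds shown leave open whether piperidin-1-yl or dimethylamino on the same carbonyl carbon would give a similar number. They also leave open how a carboxylic acid or a primary amine would compare on the saturated ring carbon.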